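The compounds below may be only part of what the source reports. "The series", "measured", "known", "first", "only" and "open" are said of these compounds alone.

Measured so far, in an ADME assay on MRC5 cells (Homo sapiens), read by MTT assay, with a stated time of 72 h; on this read-out higher numbers stand for weaker inhibition and lower numbers for stronger inhibition:
- compound 1 `COc1ncnc2c1c(-c1ccsc1)cn2[C@@H]1O[C@H](CO)[C@@H](O)[C@H]1O` gives 75300 nM
- compound 2 `COc1nc(N)nc2c1c(-c1ccsc1)cn2[C@@H]1O[C@H](CO)[C@@H](O)[C@H]1O` gives > 100000 nM, which is a limit of the assay and not a number
- compound 3 `COc1ncnc2c1c(-c1cccs1)cn2[C@@H]1O[C@H](CO)[C@@H](O)[C@H]1O` gives 43200 nM

Compound 3 differs from compound 1 in the core, (thiophen-2-yl in place of thiophen-3-yl on an aromatic carbon). The step of a 1.7-fold lower number from compound 1 to compound 3 (0.24 log units; within the scatter) lies within the scatter, so no order between compound 1 and compound 3 can be read from it. Compound 2 carries amino in place of hydrogen on an aromatic carbon relative to compound 1. The step of an at least 1.3-fold higher number from compound 1 to compound 2 (0.12 log units; that floor lies within the scatter) is given only as a floor because compound 2 sits at the limit (the limit of > 100000 nM in this assay, at which 1 of the 3 values shown sits).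

Compound 4 `COc1nc(N)nc2c1c(-c1cccs1)cn2[C@@H]1O[C@H](CO)[C@@H](O)[C@H]1O` is not yet measured. Relative to compound 3 it carries amino in place of hydrogen on an aromatic carbon, the same change as from compound 1 to compound 2, at a place described in the same words. For compound 4 in this assay a step of about a 2.0-fold higher number from compound 3 to compound 4 (0.29 log units; within the scatter) is expected, resting on the step of an at least 1.3-fold higher number from compound 1 to compound 2 (0.12 log units; that floor lies within the scatter) seen for the same change. The estimate for compound 4 is 85000 nM, with a range from 45000 nM to 200000 nM, and a fair chance that only a limit is reported.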

Compound 4, half-maximal inhibitory concentration: > 100000 nM
Compound 4 gave a limit, no number; the forecaster's own chance of this, stated with the estimate: 40%; at least 1.1-fold (0.07 log units) between middle value and limit.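

In this assay, amino in place of hydrogen on the core of compound 3 gives an at least 2.3-fold higher number from compound 3 to compound 4 (0.36 log units; beyond the scatter), a floor only, since compound 4 stands at a limit of the assay and not at a number. On the two cores the change can be set side by side only as two floors, which shows the same direction in both pairs but gives no size that carries from one core to the other: the same change on two cores in this assay, an at least 1.3-fold higher number (0.12 log units; that floor lies within the scatter) from compound 1 to compound 2 and an at least 2.3-fold higher number (0.36 log units; beyond the scatter) from compound 3 to compound 4; the limit leaves it open whether they differ

The step between the two amino compounds cannot be read, as both values are limits, so the thiophen-2-yl and thiophen-3-yl groups stay unordered once amino is present.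

Open, from the compounds shown here alone, is how far the amino compounds lie past the limit, and whether a methyl or a chlorine on the aromatic carbon between two ring nitrogen atoms would give a readable number. Also open is whether an amine in place of the methoxy group would leave the values at the same limit: the limit of > 100000 nM in this assay, at which 2 of the 4 values shown sit.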